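The source may hold more compounds than are shown below. What is called first, only, known or untested is meant among the compounds shown, and "the series" means these compounds.

The series shares a core in which an oxazole carbonyl is joined through a piperazine to an aryl group, and three members have been run in a functional assay on HL-60 cells (Homo sapiens) for inhibition, read by MTT assay, with a stated time of 72 h; on this read-out lower numbers stand for stronger inhibition and higher numbers for weaker inhibition. Compound 1 `C=C(C)c1cccc(N2CCN(C(=O)c3oc(C)nc3-c3ccccc3F)CC2)c1` is recorded in this assay as "not active" (no number reported). Compound 2 `Cc1nc(-c2ccccc2)c(C(=O)N2CCN(c3cccc(C(N)=O)c3)CC2)o1` gives 71 nM in this assay, the higher of the two numbers reported. Compound 3 `COc1cc(OC)cc(N2CCN(C(=O)c3oc(C)nc3-c3cccc(F)c3)CC2)c1` gives 28.2 nM in this assay, a lower number than compound 2 by a margin that lies beyond the usual scatter.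

Compound 4 `Cc1nc(-c2ccccc2)c(C(=O)N2CCN(c3cccc(Cl)c3Cl)CC2)o1` has not yet been measured. It differs from compound 2 in one place: 2,3-dichlorophenyl in place of 3-carbamoylphenyl on an amine nitrogen in a ring. Within the data shown here, no single-change step between measured compounds is available to calibrate this particular exchange, and the three measured compounds each carry a different aryl group on the piperazine nitrogen, so the size of the step can only be judged loosely. Given that compound 1, which likewise lacks any hydrogen-bond donor or acceptor on that aryl ring, is recorded as "not active" (no number reported), a weakening is expected, and the step from compound 2 to compound 4 is estimated at a 2.3-fold higher number from compound 2 to compound 4 (0.35 log units; beyond the scatter). Compound 4 is therefore expected to give about 160 nM in this assay, within a range from 40 nM to 800 nM.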

Compound 4, half-maximal inhibitory concentration: 133 nM
Estimate against measurement, compound 4: 1.2-fold (0.08 log units) above; the measured number falls inside the stated range.
By their numbers in this assay, from the lowest: compound 3; then compounds 2 and 4 (each within the scatter of the next).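

This gives the series its first single-change step: in this assay, placing 2,3-dichlorophenyl in the position of 3-carbamoylphenyl on the amine nitrogen in the ring gives a 1.9-fold higher number from compound 2 to compound 4 (0.27 log units; within the scatter) on this read-out. The two compounds therefore cannot be told apart here, although the hydrogen-bond donor and acceptor counted on the leaving group are absent from the entering group, so at this position the carbamoyl group is not needed for compound 4 to return a number rather than a "not active" record. Nothing measured on these compounds speaks to why the exchange leaves the result within the scatter.

Compound 1 and compound 3 differ from compound 4 in more than one place, so what separates their results from this pair cannot be read as a step. From the compounds shown here alone, whether an aryl ring on that nitrogen carrying a carboxylic acid, an amine or a single chlorine would also stay within the scatter of compound 2 remains open, as does whether 2,3-dichlorophenyl would behave the same way with a fluorophenyl group on the shared core.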